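The source may hold more compounds than are shown below. What is called first, only, known or untested is meant among the compounds shown, and "the series" means these compounds.

Compound 1 `CCN(CC)CCCC(C)/N=C(/N)NC(=O)c1cccc(Cl)c1CCc1cc(Br)ccc1OC` — in a functional assay for antagonist activity at Melanocortin receptor 4 (Homo sapiens), read by cAMP accumulation (on this read-out higher numbers stand for weaker inhibition and lower numbers for stronger inhibition), compound 1 gives 260 nM.
Compound 2 `COc1ccc(Br)cc1CCc1c(F)cccc1C(=O)/N=C(\N)NCCCN1CCCCC1` — in this assay compound 2 gives 330 nM.

Compound 2 sits at the upper end of these two figures, but its distance from compound 1 lies within the usual scatter, so the two compounds cannot be separated on this read-out. Compound 3 `COc1ccc(Br)cc1CCc1c(F)cccc1C(=O)/N=C(\N)NCCCN1CCN(C)CC1` departs from compound 2 by a single change: 4-methylpiperazin-1-yl in place of piperidin-1-yl on a saturated chain carbon, three bonds along the chain from an amine nitrogen. For the measured compounds named here, no pair of measured compounds shows this change, so the data give no measured step to lean on. With nothing beyond the scatter between the two measured compounds, compound 3 is expected to stay close to compound 2, and the step of a 1.1-fold higher number from compound 2 to compound 3 (0.03 log units; within the scatter) is estimated to be small and of uncertain direction, not clearly beyond the scatter. Compound 3 is therefore expected to give about 350 nM in this assay, within a range from 120 nM to 1000 nM.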

Compound 3, half-maximal inhibitory concentration: 670 nM
For compound 3 the middle estimate is 1.9-fold (0.28 log units) below the measured one, and the stated range covers the measured number.
By their numbers in this assay, from the lowest: compounds 1 and 2 (each within the scatter of the next); then compound 3.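

Placing 4-methylpiperazin-1-yl instead of piperidin-1-yl on the saturated chain carbon gives a 2.0-fold higher number from compound 2 to compound 3 (0.31 log units; beyond the scatter) in this assay, so the group at this position does influence the read-out, although the step is modest and points towards weaker inhibition. Compounds 1 and 2 could not show this: they differ in more than one place, and their values lie within the scatter of each other. Nothing at hand explains why this change weakens inhibition.

The compounds shown leave open whether the step follows from the second ring nitrogen or from the methyl on it, a question that piperazin-1-yl and morpholin-4-yl at the same position would help to separate. They also leave open whether the same change would give a similar step on a longer chain.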